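Replacing furan-2-yl with 4-aminophenyl

A few compounds are considered here, and "the series" means these few. Any claim that something is new, unique, unknown or untested is made for them only; others in the source may bear on it.

In an ADME assay on a cell-free system (plasma, Rattus norvegicus) for metabolic stability, read by LC-MS, with a stated time of 4 h, tested at 100 uM (a lower number here means that less of the compound is left, a higher number that more of the compound is left), compound 1 `O=C(NO)c1cc(F)c(Cn2nnc(-c3ccco3)n2)c(F)c1` gives 100%. Compound 2 `Cn1c(Sc2c(F)cc(C(=O)NO)cc2F)nnc1-c1cccnn1`, built quite differently, gives 98%, and these two values lie within the usual scatter of each other. Compound 1 therefore shares its place with compound 2, close to full recovery.

Compound 3 `Nc1ccc(-c2nnn(Cc3c(F)cc(C(=O)NO)cc3F)n2)cc1` keeps the core of compound 1 but carries 4-aminophenyl in place of furan-2-yl on an aromatic carbon. Going by the values given here, no measured pair differs in one place only, so the data show no direct precedent for this swap. Among the compounds with values here, the only guide is that compound 2, with its different groups, reads 98%, much like compound 1. The estimate is a small downward shift a number 5 percentage points lower from compound 1 to compound 3 (within the scatter), not beyond the scatter. For compound 3 the expected value is 95%, with an estimated range from 84% to 103%.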

Compound 3, percent of the compound remaining: 77%
Beside the measured number, compound 3's estimate is 18 percentage points above it, outside the stated range (below it).
By their numbers in this assay, from the lowest: compound 3; then compounds 2 and 1 (each within the scatter of the next).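

In this assay, 4-aminophenyl in place of furan-2-yl on an aromatic carbon of the shared core gives a number 23 percentage points lower from compound 1 to compound 3 (beyond the scatter). Going by these compounds alone, this is the first comparison here in which only one group differs, and it shows that this position is not indifferent to what it carries: with the rest of the molecule unchanged, less of the compound is left with the new group in place. Nothing measured here explains this drop or shows what happens to the compound.

The data do not separate the amine from the six-membered aromatic ring that carries it, so either could go with the lower number. A plain phenyl at this position would tell the two apart, and a 4-methoxyphenyl would show how a different group on that ring reads.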